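A few compounds are considered here, and "the series" means these few. Any claim that something is new, unique, unknown or untested is made for them only; others in the source may bear on it.

Compound 1 `CCCCCCCCCc1ccc(OP(=O)(O)OC[C@H]2O[C@@H](n3cc(F)c(=O)[nH]c3=O)C[C@@H]2OC(=O)c2ccccc2)cc1`: 40100 nM
Compound 2 `O=C(O[C@H]1C[C@H](n2cc(F)c(=O)[nH]c2=O)O[C@@H]1COP(=O)(O)Oc1ccc2ncccc2c1)c1ccccc1`: 7300 nM
Compound 3 `C[n+]1cccc(OP(=O)([O-])OC[C@H]2O[C@@H](n3cc(F)c(=O)[nH]c3=O)C[C@@H]2OC(=O)c2ccccc2)c1`: 1260 nM

In a functional assay on HeLa cells (Homo sapiens) for cytotoxicity, read by MTT assay, with a stated time of 48 h (a higher number here means a weaker inhibitor, a lower number a stronger inhibitor), compound 3 (1260 nM) has the lowest of the three numbers. Compound 2 (7300 nM) is nearest and compound 1 (40100 nM) furthest, both beyond the scatter.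

Compound 4 `CCCCCCCCCC[n+]1cccc(OP(=O)([O-])OC[C@H]2O[C@@H](n3cc(F)c(=O)[nH]c3=O)C[C@@H]2OC(=O)c2ccccc2)c1` differs from compound 3 by nonyl in place of hydrogen on a saturated chain carbon bound to an aromatic nitrogen, that is, methyl to decyl (nonyl in place of hydrogen on a saturated chain carbon bound to an aromatic nitrogen). Within the data shown here, no measured pair shows this change alone, so the size of the step is poorly fixed. Among the measured compounds shown here, compound 1, the only measured compound bearing a nonyl group, gives 40100 nM and tilts the expectation upward. The expected 2.4-fold higher number from compound 3 to compound 4 (0.38 log units; beyond the scatter) is a modest move to a higher number in this assay, just beyond the scatter. For compound 4 the estimated value is 3000 nM, with an expected range from 600 nM to 15000 nM.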

Compound 4, half-maximal inhibitory concentration: 1200 nM
For compound 4 the middle estimate is 2.5-fold (0.40 log units) above the measured one; the measured number falls inside the stated range.
By their numbers in this assay, from the lowest: compounds 4 and 3 (each within the scatter of the next); then compound 2; then compound 1.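

In this assay, methyl and decyl at this position give numbers within the scatter of each other: a 1.1-fold lower number from compound 3 to compound 4 (0.02 log units; within the scatter). Among these compounds, this is the first pair to differ in one place, and it shows that nonyl in place of hydrogen on a saturated chain carbon bound to an aromatic nitrogen does not separate the two compounds. No measurement at hand bears on the reason for this result. Open, on these data alone, is whether a longer chain, or a carboxylic acid or an amine at the end of the decyl chain, would keep the number in this range.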